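The source may hold more compounds than are shown below. What is called first, only, known or untested is meant among the compounds shown, and "the series" means these compounds.

Measured so far:
Compound 1 `CCOC(=O)/C=C/c1ccncc1-c1ccc2c(cnn2C)c1` — 100%
Compound 2 `Cn1ncc2cc(-c3cnccc3/C=C/C(=O)N3CCOCC3)ccc21` — 95%
Compound 3 `CCOC(=O)/C=C/c1ccncc1-c1ccc2c(ccn2C)c1` — 100%

In an assay on a protein complex for inhibition of CDK8/Cyclin C (Homo sapiens), with a stated time of 1 h, tested at 10 uM (on this read-out lower numbers stand for less inhibition and higher numbers for more inhibition at the one concentration tested (going by the name of the read-out)), compound 1 gives 100%. Compound 2 carries one change against compound 1, namely (morpholin-4-yl in place of ethoxy on a carbonyl carbon), and in this assay compound 2 gives 95%, so that a number 5 percentage points lower from compound 1 to compound 2 (within the scatter). Compound 3 rests on a different core from compound 1; the difference between the two cores is not broken down here. In this assay compound 3 gives 100%, level with compound 1 at the digits given.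

Compound 4 `Cn1ccc2cc(-c3cnccc3/C=C/C(=O)N3CCOCC3)ccc21` has not yet been measured. Against compound 3 it shows (morpholin-4-yl in place of ethoxy on a carbonyl carbon), the same change that separates compound 2 from compound 1, at a place described in the same words. Since that change produced a step within the usual scatter between compound 1 and compound 2, the step of a number 5 percentage points lower from compound 3 to compound 4 (within the scatter) is expected to be similarly small, because a number 5 percentage points lower from compound 1 to compound 2 (within the scatter) on the other core. Compound 4 is therefore estimated to reach 95% in this assay, most likely between 85% and 100%.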

Compound 4, a percentage reported as inhibition, at one concentration (the size of the read-out at that concentration, not a potency): 97%
The estimate for compound 4 lay 2 percentage points below the measured number; low and high end bracket the measured number.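

Putting morpholin-4-yl in place of ethoxy on the carbonyl carbon gives in this assay a number 3 percentage points lower from compound 3 to compound 4 (within the scatter) and so leaves the reading about where it was on this second core. Set beside the earlier case, the change carries over between the two cores with the same small outcome: the same change on two cores in this assay, a number 5 percentage points lower (within the scatter) from compound 1 to compound 2 and a number 3 percentage points lower (within the scatter) from compound 3 to compound 4, 2 percentage points apart, within the scatter of two such steps. This does not show that the two cores respond alike in potency: each number is a reading at one concentration, and compound 1, compound 2, compound 3 and compound 4 all sit near the top of the scale, where a real difference could stay hidden.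

The compounds shown leave open what other groups on the carbonyl carbon would do, such as an open-chain amine like dimethylamino or a free carboxylic acid in place of the ester. They also leave open whether the morpholin-4-yl change would behave the same way at lower concentrations or on a third core.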